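The source may hold more compounds than are shown below. What is called first, only, known or untested is meant among the compounds shown, and "the series" means these compounds.

Measured compounds:
compound 1 `COc1cc2c(Oc3ccc(NC(=O)c4cn(-c5ccccc5F)nn4)cc3F)ccnc2cc1OCCCN1CCC(C)CC1` — 190 nM
compound 2 `COc1cc2c(Oc3ccc(NC(=O)c4cn(-c5ccccc5C)nn4)cc3F)ccnc2cc1OCCCN1CCC(C)CC1` — 2730 nM
compound 3 `COc1cc2c(Oc3ccc(NC(=O)c4cn(-c5ccccc5F)nn4)cc3F)ccnc2cc1OCCCN1CCN(C)CC1` — 230 nM

These three were tested in a functional assay on NCI-H460 cells (Homo sapiens) for cytotoxicity, read by MTT assay, with a stated time of 72 h; on this read-out lower numbers stand for stronger inhibition and higher numbers for weaker inhibition. The change from compound 1 to compound 2 is methyl in place of fluoro on an aromatic carbon, and it produced a 14-fold higher number from compound 1 to compound 2 (1.16 log units; beyond the scatter). The two cores differ by 4-methylpiperazin-1-yl in place of 4-methylpiperidin-1-yl on a saturated chain carbon, three bonds along the chain from an oxygen on an aromatic ring, a change that gave a 1.2-fold higher number from compound 1 to compound 3 (0.08 log units; within the scatter), so compound 1 and compound 3 are treated as equivalent starting points.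

Compound 4 `COc1cc2c(Oc3ccc(NC(=O)c4cn(-c5ccccc5C)nn4)cc3F)ccnc2cc1OCCCN1CCN(C)CC1` carries the same change made from compound 3: methyl in place of fluoro on an aromatic carbon. The surroundings of the change are the same in both pairs. Among the measured compounds shown here, its step in this assay, an 11-fold higher number from compound 3 to compound 4 (1.05 log units; beyond the scatter), is expected to match the earlier one, because a 14-fold higher number from compound 1 to compound 2 (1.16 log units; beyond the scatter) is the only precedent and it lies well beyond the scatter. Compound 4 is therefore estimated at 2600 nM, with a likely range from 900 nM to 7500 nM.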

Compound 4, half-maximal inhibitory concentration: 3650 nM
Beside the measured number, compound 4's estimate is 1.4-fold (0.15 log units) below it, within the range that was stated.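

In this assay, methyl in place of fluoro on the aromatic carbon carried over from one core to the other, giving a 16-fold higher number from compound 3 to compound 4 (1.20 log units; beyond the scatter), and the two steps agree: the same change on two cores in this assay, a 14-fold higher number (1.16 log units; beyond the scatter) from compound 1 to compound 2 and a 16-fold higher number (1.20 log units; beyond the scatter) from compound 3 to compound 4, 1.1-fold (0.04 log units) apart, within the scatter of two such steps. The exchange of 4-methylpiperidin-1-yl for 4-methylpiperazin-1-yl also stayed small on the 2-methylphenyl compounds, at a 1.3-fold higher number from compound 2 to compound 4 (0.13 log units; within the scatter), and it agrees with the same exchange on the 2-fluorophenyl compounds: the same change on two cores in this assay, a 1.2-fold higher number (0.08 log units; within the scatter) from compound 1 to compound 3 and a 1.3-fold higher number (0.13 log units; within the scatter) from compound 2 to compound 4, 1.1-fold (0.04 log units) apart, within the scatter of two such steps. This agreement rests on just two cores in a single assay, so it does not show that either change would carry over in the same way to other cores, nor does it explain the size of the step.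

The compounds shown leave open how chloro or methoxy in place of the fluoro or methyl would fare. They also leave open what a morpholine on the saturated chain would give.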